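The compounds below may be only part of what the source reports. "The series", "measured", "known", "first", "only" and "open" are said of these compounds alone.

Of the compounds shown here, three sharing one core have been measured in a functional assay on MCF7R cells (Homo sapiens) for cytotoxicity, tested at 10 uM; a lower number here means less inhibition, a higher number more inhibition at the concentration tested (going by the name of the read-out). Compound 1 `O=Cc1c(-c2ccccc2)sc2ccccc12` gives 37%. Compound 2 `COc1ccc(-c2sc3ccccc3c2C=O)cc1` gives 80%, and compound 3 `O=Cc1c(-c2ccc(C(F)(F)F)cc2)sc2ccccc12` gives 59%. Compound 3 therefore stands second highest of the three: the step of a number 22 percentage points higher from compound 1 to compound 3 (beyond the scatter) lies beyond the scatter, and so does the step of a number 21 percentage points lower from compound 2 to compound 3 (beyond the scatter). The largest step seen is a number 43 percentage points higher from compound 1 to compound 2 (beyond the scatter).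

Compound 4 `O=Cc1c(-c2ccc(Cl)cc2)sc2ccccc12` has not yet been measured. It differs from compound 3 in one place: chloro in place of trifluoromethyl on an aromatic carbon. Within the data shown here, no measured step exchanges trifluoromethyl for chloro, so the steps that bear on it are indirect. Two different groups placed on that aromatic carbon gave the steps of a number 43 percentage points higher from compound 1 to compound 2 (beyond the scatter) and a number 22 percentage points higher from compound 1 to compound 3 (beyond the scatter), both upward, while exchanging one of those groups for the other gave a number 21 percentage points lower from compound 2 to compound 3 (beyond the scatter). Chloro is a third group on that aromatic carbon, and the data give no way to rank it against the other two. Compound 4 is therefore expected to sit close to the trifluoromethyl analogue, the expected step being a number 4 percentage points lower from compound 3 to compound 4 (within the scatter), within the scatter. The estimate for compound 4 in this assay is 55%, with a range from 35% to 78%.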

Compound 4, a percentage reported as inhibition, at one concentration (the size of the read-out at that concentration, not a potency): 35%
Beside the measured number, compound 4's estimate is 20 percentage points above it, and the stated range covers the measured number.
By their numbers in this assay, from the lowest: compounds 4 and 1 (each within the scatter of the next); then compound 3; then compound 2.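

Among these compounds, until this result, both groups placed on this aromatic carbon had given a higher number than hydrogen in this assay, but chloro breaks that pattern, with a number 2 percentage points lower from compound 1 to compound 4 (within the scatter); a substituent here therefore does not in itself raise the number. The position does separate the three groups clearly: exchanging trifluoromethyl for chloro gives a number 24 percentage points lower from compound 3 to compound 4 (beyond the scatter), and exchanging methoxy for chloro gives a number 45 percentage points lower from compound 2 to compound 4 (beyond the scatter), which leaves methoxy with the highest number of the four compounds and chloro not distinguishable from hydrogen. Nothing available here accounts for why these groups differ in this way.

The compounds shown leave open whether other groups on this aromatic carbon, such as an amine, a hydroxyl or a longer ether like ethoxy, would follow methoxy or chloro, and whether methoxy would give a similar number on a different carbon of the same ring. They also leave open how far the aldehyde matters, since all four compounds keep it, so a carboxylic acid or an amide in its place could behave quite differently, and a reading at one concentration gives no potency for any of them.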